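This account rests on a few compounds, and the source may have more. Where it says the series, first, only, none or still open, it means among the compounds named here.

Compound 1 `CCOC(=O)/C=C/c1ccc(OCc2nc(C)c(C)nc2C)c(O)c1` and compound 2 `CCOC(=O)/C=C/c1cccc(OCc2nc(C)c(C)nc2C)c1` share a core, and the difference between the two cores is not broken down here. Compound 3 `Cc1nc(C)c(COc2ccc(/C=C/C(=O)O)cc2O)nc1C` is compound 1 with one change, (hydrogen in place of ethyl on an oxygen next to a carbonyl group). In a functional assay on a cell-free system (Platelet, plasma, Oryctolagus cuniculus) for inhibition, with a stated time of 5 min (on this read-out higher numbers stand for weaker inhibition and lower numbers for stronger inhibition), compound 1 gives 1380000 nM, and in this assay compound 3 gives 176000 nM, so the change made the step of a 7.8-fold lower number from compound 1 to compound 3 (0.89 log units; beyond the scatter). In this assay compound 2 gives 628000 nM.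

Compound 4 `Cc1nc(C)c(COc2cccc(/C=C/C(=O)O)c2)nc1C` has not yet been measured. Going by the values given here, it is compound 2 with the same change, (hydrogen in place of ethyl on an oxygen next to a carbonyl group), made at the same place as the one seen from compound 1 to compound 3. Because the earlier step was a 7.8-fold lower number from compound 1 to compound 3 (0.89 log units; beyond the scatter), a step of about the same size is expected here, giving a 7.4-fold lower number from compound 2 to compound 4 (0.87 log units; beyond the scatter). Starting from compound 2, the value of compound 4 in this assay is therefore estimated at 85000 nM, most likely between 35000 nM and 210000 nM.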

Compound 4, half-maximal inhibitory concentration: 161000 nM
Compound 4: the middle estimate sits 1.9-fold (0.28 log units) below what was measured; the range from low to high includes it.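

In this assay, replacing the ethyl on the ester oxygen with hydrogen, which turns ethoxycarbonyl into carboxy, gave a 3.9-fold lower number from compound 2 to compound 4 (0.59 log units; beyond the scatter) and so stronger inhibition, the same direction as on the core of compound 1. Going by these compounds alone, this rests on only two pairs of compounds, so it does not show that the change would behave the same way on other cores, and it does not explain why inhibition strengthens. Within these two pairs, the size of the step also carried over from one core to the other, as far as the scatter of the measurements can tell: the same change on two cores in this assay, a 7.8-fold lower number (0.89 log units; beyond the scatter) from compound 1 to compound 3 and a 3.9-fold lower number (0.59 log units; beyond the scatter) from compound 2 to compound 4, 2.0-fold (0.30 log units) apart, within the scatter of two such steps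

From the compounds shown here alone, it remains open whether a methyl group or a longer chain on that oxygen would fit between or beyond the ethyl and hydrogen results, and whether an amide in place of the carboxy group would give similar inhibition. Going by these compounds, the difference between the two cores also remains unresolved, so what each part of it contributes on its own is unknown.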